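A Single Stereocentre Inverted on a Cytotoxic Scaffold

This account rests on a few compounds, and the source may have more. Where it says the series, first, only, none or still open, it means among the compounds named here.

Compound 1, `CC(=O)O[C@@H]1C(=O)CCC2=CC(=O)C[C@H](C)[C@@]2(C)/C=C\1C`: in a functional assay on HT-29 cells (Homo sapiens) for cytotoxicity (a lower number here means that less compound is needed, a higher number that more compound is needed for the effect), compound 1 gives > 5 ug/mL, which is a limit of the assay and not a number.
Compound 2, `CC(=O)[C@H]1[C@@H](O)CCC2=C[C@@H](O)C[C@H](C)[C@]21C`: in this assay compound 2 gives > 5 ug/mL, again a limit rather than a number.

Compound 2 stands at the limit of > 5 ug/mL in this assay, at which 2 of the 2 values shown sit. Among the measured compounds shown here, nothing in the two values shown sets compound 2 apart from compound 1, and no pair of measured compounds differs in a single place, so no measured step size is available.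

Compound 3, `CC(=O)[C@H]1[C@H](O)CCC2=C[C@@H](O)C[C@H](C)[C@]21C`, has not yet been measured. It differs from compound 2 as follows: the two compounds have the same atoms and bonds and differ only in configuration as drawn: 1 of 5 stereo elements differ; a stereocentre at a saturated ring carbon is drawn S in compound 2 and R in compound 3.

With both measured values sitting at a limit, the step from compound 2 to compound 3 is expected to be a step that the limit leaves unreadable from compound 2 to compound 3, that is, none beyond the usual scatter in either direction. Compound 3 is accordingly estimated at 10 ug/mL, with a range from 3 ug/mL to 40 ug/mL, and most probably it will again be reported only as a limit.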

Compound 3, concentration for half-maximal effect: > 5 ug/mL
Compound 3: only a limit was reported; the forecaster's own chance of this, stated with the estimate: 80%; the middle value does not contradict the limit.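

In this assay compound 3 gives > 5 ug/mL, again a limit and not a number. Among the compounds shown here, compound 2 and compound 3 both stand at a limit, so no step between them can be read. The compounds shown leave open how much of either is needed for the effect, and whether this inverted stereocentre changes that amount at all.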